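This account rests on a few compounds, and the source may have more. Where it says the series, first, only, none or still open, it means among the compounds named here.

The three measured compounds:
compound 1 `COc1cc(Cc2cnc(/N=C3\C(=O)N(CN4CCCCC4C)c4ccc(Cl)cc43)nc2N)cc(OC)c1OC`, which in an ADME assay on MT4 cells (Homo sapiens) for cytotoxicity, read by MTT assay, with a stated time of 5 days (on this read-out lower numbers stand for higher toxicity in this test and higher numbers for lower toxicity in this test), gives 97.3 ug/mL;
compound 2 `COc1cc(Cc2cnc(/N=C3\C(=O)N(CN4CCN(Cc5ccccc5)CC4)c4ccc(Cl)cc43)nc2N)cc(OC)c1OC`, which gives 36.1 ug/mL;
compound 3 `CCCCN(CCCC)CN1C(=O)/C(=N\c2ncc(Cc3cc(OC)c(OC)c(OC)c3)c(N)n2)c2cc(Cl)ccc21`, which gives 62.6 ug/mL.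

Compound 2 gives the lowest of the three numbers. Its number and that of compound 3 lie within the scatter of each other, while compound 1 stands beyond the scatter above it. Compound 4 `COc1cccc(N2CCN(CN3C(=O)/C(=N\c4ncc(Cc5cc(OC)c(OC)c(OC)c5)c(N)n4)c4cc(Cl)ccc43)CC2)c1` is not yet measured. It differs from compound 2 in one place: 3-methoxyphenyl in place of benzyl on an amine nitrogen in a ring. Among the compounds with values here, the only measured step, a 1.6-fold lower number from compound 1 to compound 3 (0.19 log units; within the scatter), concerns another place and was within the scatter, so no measured step bears on this change. With nothing pointing either way, the number for compound 4 is expected to stay close to that of compound 2, a step of a 1.2-fold higher number from compound 2 to compound 4 (0.07 log units; within the scatter) in this assay. Compound 4 is therefore estimated at 42 ug/mL, with a range from 18 ug/mL to 95 ug/mL.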

Compound 4, half-maximal cytotoxic concentration: 32.6 ug/mL
For compound 4 the middle estimate is 1.3-fold (0.11 log units) above the measured one; the range from low to high includes it.
By their numbers in this assay, from the lowest: compounds 4, 2, 3 and 1 (each within the scatter of the next, the first and the last beyond it).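

Within the data shown here, this is the first measured step at this position: in this assay, 3-methoxyphenyl in place of benzyl on the amine nitrogen in the ring gives a 1.1-fold lower number from compound 2 to compound 4 (0.04 log units; within the scatter). The two compounds therefore cannot be told apart here, even though the entering group carries an oxygen and a hydrogen-bond acceptor that benzyl lacks. No measurement at hand explains this result.

Plain phenyl would show whether the methoxy group or the missing carbon between ring and nitrogen matters more. A carboxylic acid or an amine on that aromatic ring remains an open test of this position.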